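The source may hold more compounds than are shown below. What is called first, only, known or untested is meant among the compounds shown, and "the series" means these compounds.

Measured in an ADME assay on microsomes from liver (Rattus norvegicus) for metabolic stability, read by LC-MS, using NADPH, at 37 degrees C; on this read-out lower numbers stand for a shorter-lived compound and higher numbers for a longer-lived compound:

- compound 1 `Cc1cc(C)c(-c2nc(CN3CCC(C(=O)NCCCN4C[C@H](C)C[C@H](C)C4)CC3)c(C)o2)c(C)c1`: > 0.5 h
- compound 2 `Cc1ccccc1-c1nc(CN2CCC(C(=O)NCCCN3CCC(C(C)C)CC3)CC2)c(C)o1`: 0.147 h

Compound 1 stands at > 0.5 h, which is a limit of the assay and not a number. Compound 1 and compound 2 differ in more than one place, and compound 2 gives a plain number of 0.147 h.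

Compound 3 `Cc1oc(-c2c(Cl)cccc2Cl)nc1CN1CCC(C(=O)NCCCN2C[C@H](C)C[C@H](C)C2)CC1` keeps the rest of compound 1 and has 2,6-dichlorophenyl in place of 2,4,6-trimethylphenyl on an aromatic carbon. Among the measured compounds shown here, no measured pair shows this change alone, so the expectation in this assay rests on compound 1 and its limit of > 0.5 h. The expected step that the limit leaves unreadable from compound 1 to compound 3 is none beyond the usual scatter, in either direction. The assay may again report only a limit. For compound 3 the estimated half-life is 0.6 h, with an expected range from 0.25 h to 1.5 h.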

Compound 3, half-life: 0.0483 h
Estimate against measurement, compound 3: 12-fold (1.09 log units) above; the whole stated range lies above it.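

In this assay, the group at this place on the five-membered aromatic ring carries real weight: with the rest of the molecule unchanged, putting 2,6-dichlorophenyl in place of 2,4,6-trimethylphenyl gives an at least 10-fold lower number from compound 1 to compound 3 (1.01 log units; beyond the scatter). Among the compounds shown here, the earlier compounds offered no pair that isolated this position, so this is the first direct sign that the half-life responds to a change here. Compound 1 stands at a limit and not a number: the limit of > 0.5 h in this assay, at which 1 of the 3 values shown sits.

The compounds shown leave open whether the drop goes with the two chlorine atoms or with the loss of the methyl groups, and a 2,6-dimethylphenyl group at the same place would separate these two readings. On these data alone, how a plain phenyl or a 2,6-difluorophenyl group would fare on this core also remains open.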